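Series notes: aryl group on the piperazine nitrogen

The compounds below may be only part of what the source reports. "The series", "measured", "known", "first", "only" and "open" are said of these compounds alone.

In an ADME assay on MT4 cells (Homo sapiens) for cytotoxicity, read by MTT assay, with a stated time of 5 days (a lower number here means that less compound is tolerated, a higher number that more compound is tolerated), compound 2 `COc1cc(Cc2cnc(/N=C3\C(=O)N(CN4CCN(c5cccc(Cl)c5)CC4)c4ccc(Cl)cc43)nc2N)cc(OC)c1OC` gives 39.2 ug/mL. Compound 1 `COc1cc(Cc2cnc(/N=C3\C(=O)N(CN4CCN(Cc5ccccc5)CC4)c4ccc(Cl)cc43)nc2N)cc(OC)c1OC` gives 36.1 ug/mL in this assay, and the step of a 1.1-fold higher number from compound 1 to compound 2 (0.04 log units; within the scatter) is within the scatter. Compound 3 `COc1cc(Cc2cnc(/N=C3\C(=O)N(CN4CCN(c5ccc(F)cc5)CC4)c4ccc(Cl)cc43)nc2N)cc(OC)c1OC` carries the change (4-fluorophenyl in place of 3-chlorophenyl on an amine nitrogen in a ring). Among the compounds with values here, the only measured step touching this ring nitrogen, a 1.1-fold higher number from compound 1 to compound 2 (0.04 log units; within the scatter), did not move the number beyond the scatter, so for compound 3 a step of a 1.0-fold lower number from compound 2 to compound 3 (0.01 log units; within the scatter) is expected, no larger than the scatter, with no direction indicated. Compound 3 is estimated at 38 ug/mL, range 20 ug/mL to 70 ug/mL.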

Compound 3, half-maximal cytotoxic concentration: 65.6 ug/mL
For compound 3 the middle estimate is 1.7-fold (0.24 log units) below the measured one; measured number inside the range.
By their numbers in this assay, from the lowest: compounds 1, 2 and 3 (each within the scatter of the next).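

In this assay, 4-fluorophenyl in place of 3-chlorophenyl on an amine nitrogen in a ring gives a 1.7-fold higher number from compound 2 to compound 3 (0.22 log units; within the scatter), and 4-fluorophenyl in place of benzyl gives a 1.8-fold higher number from compound 1 to compound 3 (0.26 log units; within the scatter). All three aryl-containing groups at this nitrogen therefore stand within the scatter of one another, including across a swap of chlorine for fluorine on the phenyl ring. No evidence on the reason for this is available. Still open, as far as these compounds go, is whether a different kind of group on this nitrogen, such as a carboxylic acid or a longer chain ending in an amine, would move the number beyond the scatter.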